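The source may hold more compounds than are shown below. What is called first, only, known or untested is meant among the compounds shown, and "the series" means these compounds.

Working notes on the series, cytotoxicity.

Compound 1 `CC(C)n1ncc2c(C(=O)Nc3ncccn3)cc(-c3cccs3)nc21` was run in an ADME assay on LLC-MK2 cells (Macaca mulatta) for cytotoxicity, read by spectrophotometry and crystal violet staining, with a stated time of 4 days (on this read-out lower numbers stand for higher toxicity in this test and higher numbers for lower toxicity in this test), and gives 75000 nM. Compound 3 `CC(C)n1ncc2c(C(=O)Nc3ccccc3F)cc(-c3cncs3)nc21` gives 100000 nM in this assay, a gap from compound 1 that lies within the usual scatter, so no order between the two is claimed; together they are the two numbers measured. Compound 2 `CC(C)n1ncc2c(C(=O)Nc3ccc(F)cc3)cc(-c3ccsc3)nc21` reaches only a limit in this assay, > 200000 nM, and that is all this value says. The data show (the limit of > 200000 nM in this assay, at which 1 of the 3 values shown sits). For the measured compounds named here, no pair of measured compounds differs in one place, so no measured step is available for the series.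

Compound 4 `CC(C)n1ncc2c(C(=O)Nc3ccccn3)cc(-c3cccs3)nc21` has not yet been measured in this assay. It differs from compound 1 in one place: pyridin-2-yl in place of pyrimidin-2-yl on an amide-type nitrogen. The three aryl amides measured so far, differing at both ends of the core, give numbers or a limit that all sit in the same upper region of this assay, and nothing measured singles out the amide substituent as a driver of toxicity here. The expected step from compound 1 to compound 4 in this assay is therefore none beyond the scatter, a 1.1-fold higher number from compound 1 to compound 4 (0.05 log units; within the scatter). Compound 4 is expected to give about 85000 nM in this assay, in the range 35000 nM to 200000 nM.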

Compound 4, half-maximal cytotoxic concentration: > 200000 nM
Compound 4 gave a limit, no number (the forecaster's own chance of this, stated with the estimate: 30%); middle value at least 2.3-fold (0.37 log units) away from the limit.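

For the compounds shown here, the amide substituent is the first place with a measured single-place step: in this assay, pyridin-2-yl in place of pyrimidin-2-yl on an amide-type nitrogen gives an at least 2.6-fold higher number from compound 1 to compound 4 (0.42 log units; beyond the scatter), which lies beyond the scatter and points to lower toxicity in this test. The change is small as counted, since both groups have 6 heavy atoms and no net charge and the difference is a six-membered aromatic ring with 1 hetero atom in place of one with 2 hetero atoms, so the read-out responds at this position to a change of that size alone. Compound 4 gives a limit and not a number, so the step is a floor on the difference and its true size stays unknown, and the upper end of the read-out now holds more of the compounds shown: the limit of > 200000 nM in this assay, at which 2 of the 4 values shown sit.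

The compounds shown leave open whether the same step holds with the other aryl groups carried by the core, since only the thiophene-bearing pair gives a single-place comparison. They also leave open where pyrazin-2-yl or an unsubstituted phenyl on the amide-type nitrogen would fall in this assay, and so whether ring nitrogen count tracks the read-out at all.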